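A few compounds are considered here, and "the series" means these few. Any claim that something is new, unique, unknown or untested is made for them only; others in the source may bear on it.

In a functional assay on A549 cells (Homo sapiens) for inhibition, read by MTT assay, with a stated time of 48 h (on this read-out lower numbers stand for stronger inhibition and higher numbers for weaker inhibition), compound 1 (`c1ccc(C(c2c[nH]c3ccccc23)c2c[nH]c3ccccc23)cc1`) gives 40000 nM, compound 2 (`COc1ccc(C(c2c[nH]c3ccc(Br)cc23)c2c[nH]c3ccc(Br)cc23)c(OC)c1`) gives 100000 nM and compound 3 (`CN(C)c1ccc(C(c2c[nH]c3ccc(Br)cc23)c2c[nH]c3ccc(Br)cc23)cc1`) gives 25000 nM. Compound 3 therefore lies within the usual scatter of compound 1 and clearly under compound 2. Compound 4 (`CCCC(c1c[nH]c2ccc(Br)cc12)c1c[nH]c2ccc(Br)cc12`) carries propyl in place of 4-(dimethylamino)phenyl on a saturated chain carbon bound to two aromatic carbons. Within the data shown here, the only measured step at this place is a 4.0-fold lower number from compound 2 to compound 3 (0.60 log units; beyond the scatter), and it swaps one substituted phenyl for another. Among the measured compounds shown here, no compound without a ring at this place has been measured, so the guide is weak. In this assay a modest rise is expected, the estimated step being a 1.8-fold higher number from compound 3 to compound 4 (0.26 log units; within the scatter). For compound 4 the expected value is 45000 nM, with an estimated range of 18000 nM to 110000 nM.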

Compound 4, half-maximal inhibitory concentration: 6500 nM
Estimate against measurement, compound 4: 6.9-fold (0.84 log units) above; the measured number lies below the stated range.
By their numbers in this assay, from the lowest: compound 4; then compounds 3 and 1 (each within the scatter of the next); then compound 2.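

In this assay, a ring is not required at this place on the saturated chain carbon: propyl, which has no ring, gives a 3.8-fold lower number from compound 3 to compound 4 (0.59 log units; beyond the scatter) and a 15-fold lower number from compound 2 to compound 4 (1.19 log units; beyond the scatter). The earlier step only exchanged one substituted phenyl for another, whereas these steps show that removing the ring altogether can lower the number. Nothing available explains this drop.

The compounds shown leave open how chain length affects the number, as propyl is the only ring-free group among them. A longer chain such as hexyl, or a chain ending in an amine, would be informative here.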